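The source may report more compounds than this note shows. Statements on the series, on what has been measured and on what is new or still open speak of the compounds shown alone.

Of the compounds shown here, three built on one shared core have been measured in an assay on cell membranes for displacement of a labelled ligand from corticotropin-releasing factor receptor 1 (Rattus norvegicus); a higher number here means a weaker inhibitor, a lower number a stronger inhibitor. Compound 1 `CCC(CC)Nc1nc(C)nc2c(-c3ccc(OC)nc3C)c(C)nn12` gives 3.1 nM. Compound 2 `CCCCN(CCC)c1nc(C)nc2c(-c3ccc(OC)nc3C)c(C)nn12` gives 2.4 nM. Compound 3 `CCCCC(C)Nc1nc(C)nc2c(-c3ccc(OC)nc3C)c(C)nn12` gives 5.1 nM. Among these three, compound 3 has the highest number: the step of a 1.6-fold higher number from compound 1 to compound 3 (0.22 log units; within the scatter) stays within the scatter, while the step of a 2.1-fold higher number from compound 2 to compound 3 (0.33 log units; beyond the scatter) goes beyond it, though only modestly.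

Compound 4 `CCN(CC)c1nc(C)nc2c(-c3ccc(OC)nc3C)c(C)nn12` differs from compound 3 in one place: diethylamino in place of (1-methylpentyl)amino on an aromatic carbon. The group that enters carries no hydrogen-bond donor, as is also true of the butyl(propyl)amino group of compound 2. Among the measured compounds shown here, two measured steps bear on this change. The step of a 1.3-fold lower number from compound 1 to compound 2 (0.11 log units; within the scatter) stayed within the scatter, and the step of a 2.1-fold higher number from compound 2 to compound 3 (0.33 log units; beyond the scatter) was a modest rise beyond it. Reversing that direction, from an amino group with a donor to one without, suggests at most a modest fall in this assay, and the smaller diethylamino group has no measured precedent of its own among these compounds. Compound 4 is therefore expected to give 3.5 nM in this assay, within a range from 1.5 nM to 9 nM. That would mean an expected step of a 1.5-fold lower number from compound 3 to compound 4 (0.16 log units; within the scatter).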

Compound 4, half-maximal inhibitory concentration: 12 nM
The estimate for compound 4 lay 3.4-fold (0.54 log units) below the measured number, outside the stated range (above it).
By their numbers in this assay, from the lowest: compounds 2, 1 and 3 (each within the scatter of the next, the first and the last beyond it); then compound 4.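

In this assay, the position on the aromatic carbon between two ring nitrogen atoms proved more sensitive than the three earlier compounds had shown, with diethylamino, at 5 heavy atoms, giving the highest number of the four. The absence of a hydrogen-bond donor does not sort these numbers: compound 2 and compound 4 both lack one, yet there is a 5.0-fold higher number from compound 2 to compound 4 (0.70 log units; beyond the scatter), while the compounds with a donor also lie on the lower side, with a 2.4-fold higher number from compound 3 to compound 4 (0.37 log units; beyond the scatter) and a 3.9-fold higher number from compound 1 to compound 4 (0.59 log units; beyond the scatter). The compounds shown offer no measurement that explains why diethylamino differs from the three larger amino groups.

From the compounds shown here alone, what remains open is whether the number climbs gradually or abruptly as the alkyl groups on this nitrogen shorten, which a dipropylamino or ethyl(propyl)amino group at the same place could help to settle. Going by these compounds, it is also open whether a short group that keeps the amino hydrogen, such as ethylamino or isopropylamino, would follow compound 4, and how a ring amine such as pyrrolidine or morpholine would compare.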